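The source may hold more compounds than are shown below. What is called first, only, known or untested is meant among the compounds shown, and "the series" means these compounds.

Compound 1, `CN1CCN(c2ncc3c(n2)CCN(C(=O)c2cc(Cc4n[nH]c(=O)c5ccccc45)ccc2F)C3)CC1`. In a functional assay on MDA-MB-231 cells (Homo sapiens) for inhibition, read by MTT assay, with a stated time of 48 h (a higher number here means a weaker inhibitor, a lower number a stronger inhibitor), compound 1 gives > 200000 nM, which is a limit of the assay and not a number.
Compound 2, `CCN(CC)c1ncc2c(n1)CCN(C(=O)c1cc(Cc3n[nH]c(=O)c4ccccc34)ccc1F)C2`. In this assay compound 2 gives > 200000 nM, again a limit.
Compound 3, `CCCN(CCC)c1ncc2c(n1)CCN(C(=O)c1cc(Cc3n[nH]c(=O)c4ccccc34)ccc1F)C2`. In this assay compound 3 gives > 200000 nM, also a limit.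

Compound 3 therefore stands at the edge of what this assay can report: the limit of > 200000 nM in this assay, at which 3 of the 3 values shown sit. The three compounds share one core and differ only in the amine on an aromatic carbon, and none of the steps among them can be sized, since a step that the two limits leave unreadable from compound 1 to compound 2, a step that the two limits leave unreadable from compound 1 to compound 3 and a step that the two limits leave unreadable from compound 2 to compound 3 all run from one limit to another. Compound 4, `CCCCN(CCCC)c1ncc2c(n1)CCN(C(=O)c1cc(Cc3n[nH]c(=O)c4ccccc34)ccc1F)C2`, carries the next change in the same place: dibutylamino in place of dipropylamino on an aromatic carbon. This continues the lengthening of the two chains on that nitrogen that was already covered by the step from compound 2 to compound 3, and that step gave no readable change. Going by the values given here, no step with a measurable size bears on the change, so no shift beyond the scatter is expected in this assay, and compound 4 is expected to stay at the limit. The estimated step that the limit leaves unreadable from compound 3 to compound 4 is accordingly expected to be none. Compound 4 is estimated at 300000 nM, within 100000 nM to 1000000 nM.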

Compound 4, half-maximal inhibitory concentration: > 200000 nM
Compound 4: only a limit was reported (the forecaster's own chance of this, stated with the estimate: 85%); the middle value is on the limit's open side.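

Compound 4 gives > 200000 nM in this assay, again a limit and not a number, so none of its steps from compound 1, compound 2 or compound 3 can be read. Still open is how far the amine on the shared core changes inhibition, and the four compounds offer no measured size for it: the limit of > 200000 nM in this assay, at which 4 of the 4 values shown sit.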